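The source may report more compounds than this note shows. Statements on the series, on what has been measured and on what is new or still open speak of the compounds shown alone.

Measured compounds:
compound 1 `COc1ccc2nc(C)cc(NCc3ccccc3F)c2c1` gives 17000 nM in a functional assay on MCF-10A cells (Homo sapiens) for antiproliferative activity, with a stated time of 48 h; a higher number here means that more compound is needed for the effect, a lower number that less compound is needed
compound 2 `COc1ccc2nc(C)cc(NCc3ccc(F)cc3F)c2c1` gives 15000 nM in this assay
compound 3 `COc1cccc(CNc2cc(C)nc3ccc(OC)cc23)c1` gives 12500 nM in this assay

Compound 2 differs from compound 1 by fluoro in place of hydrogen on an aromatic carbon and that change made a 1.1-fold lower number from compound 1 to compound 2 (0.05 log units; within the scatter). All three numbers lie within the scatter of one another. Compound 4 `COc1ccc2nc(C)cc(NCc3ccc(F)c(OC)c3)c2c1` has yet to be measured in this assay; it differs from compound 3 by fluoro in place of hydrogen on an aromatic carbon, the same kind of change as before, though in compound 2 the new fluoro stands meta to a fluoro group and in compound 4 it stands ortho to a methoxy group. The difference between the cores of compound 1 and compound 3 is not broken down here. Because compound 3 gives 12500 nM and the earlier change made a 1.1-fold lower number from compound 1 to compound 2 (0.05 log units; within the scatter), compound 4 is expected to show a 1.0-fold lower number from compound 3 to compound 4 (0.02 log units; within the scatter). The estimate for compound 4 is 12000 nM, expected to fall between 6000 nM and 24000 nM.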

Compound 4, half-maximal effective concentration: 12900 nM
The estimate for compound 4 lay 1.1-fold (0.03 log units) below the measured number, and the stated range covers the measured number.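

In this assay, fluoro in place of hydrogen, ortho to a methoxy group, gave a 1.0-fold higher number from compound 3 to compound 4 (0.01 log units; within the scatter). Set beside the earlier step, the same change reads alike on the two cores: the same change on two cores in this assay, a 1.1-fold lower number (0.05 log units; within the scatter) from compound 1 to compound 2 and a 1.0-fold higher number (0.01 log units; within the scatter) from compound 3 to compound 4, 1.2-fold (0.07 log units) apart, within the scatter of two such steps. Within the data shown here, this shows only that the change stayed within the scatter on both cores; with no step beyond the scatter on either, it does not show that any real effect carries over, and with the fluoro placed differently in the two pairs, it says nothing about other positions.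

The compounds shown leave open whether an amine or a carboxylic acid on the same six-membered aromatic ring would move the number beyond the scatter. They also leave open what a longer chain leading to that ring would do.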